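Methyl step from compound 3 to compound 4

The source may hold more compounds than are shown below. What is called first, only, known or untested is meant among the compounds shown, and "the series" means these compounds.

Compound 2 `COc1cc(N(Cc2ccccc2)S(=O)(=O)c2ccc(C)cc2)cc(OC)c1OC` carries a benzyl group on the sulfonamide nitrogen; in a functional assay on PC-3 cells (Homo sapiens) for inhibition, read by MTT assay, with a stated time of 48 h (a lower number here means a stronger inhibitor, a higher number a weaker inhibitor), compound 2 gives 7810 nM. Compound 1 `COc1cc(N(Cc2cccc(C)c2)S(=O)(=O)c2ccc(C)cc2)cc(OC)c1OC` differs from it by methyl in place of hydrogen on an aromatic carbon, and in this assay compound 1 gives 8580 nM. The step of a 1.1-fold higher number from compound 2 to compound 1 (0.04 log units; within the scatter) is within the scatter. Compound 3 `Cc1ccc(S(=O)(=O)N(Cc2nc3ccccc3[nH]2)c2ccccc2)cc1` has another core; the difference between the cores of compound 2 and compound 3 is not broken down here. In this assay compound 3 gives only a limit, > 50000 nM, the same limit as the limit of > 50000 nM in this assay, at which 1 of the 3 values shown sits.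

Compound 4 `Cc1ccc(N(Cc2nc3ccccc3[nH]2)S(=O)(=O)c2ccc(C)cc2)cc1` has not yet been measured. It differs from compound 3 by methyl in place of hydrogen on an aromatic carbon. This is the same kind of change as from compound 2 to compound 1, but the place differs: there the methyl enters meta to a large group, here para to a large group. For compound 4 the expected step of a number no higher from compound 3 to compound 4 (the limit leaves the size open) is small, resting on the step of a 1.1-fold higher number from compound 2 to compound 1 (0.04 log units; within the scatter) being within the scatter and on compound 3 sitting at the limit (the limit of > 50000 nM in this assay, at which 1 of the 3 values shown sits). Compound 4 is thus expected to give about 50000 nM in this assay, estimated between 20000 nM and 150000 nM, and most likely again only a limit.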

Compound 4, half-maximal inhibitory concentration: 48900 nM
Compound 4: middle estimate off by 1.0-fold (0.01 log units), on the high side, and the stated range covers the measured number.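

In this assay, methyl in place of hydrogen on an aromatic carbon, here phenyl to 4-methylphenyl, gives an at least 1.0-fold lower number from compound 3 to compound 4 (0.00 log units; that floor lies within the scatter). Compound 3 gives only a limit, > 50000 nM, and the step therefore has a floor but no known size. This shows no step beyond the scatter on either core as far as the values can be read, but it does not show that the change carries over with the same size from one core to the other: the same change on two cores in this assay, a 1.1-fold higher number (0.04 log units; within the scatter) from compound 2 to compound 1 and an at least 1.0-fold lower number (0.00 log units; that floor lies within the scatter) from compound 3 to compound 4; the limit leaves it open whether they differ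

The compounds shown leave open whether an amine or a carboxylic acid in place of this methyl would move the number in this assay beyond the scatter on either core. Also open, on these data alone, is how a methyl para to a large group reads on the core of compound 2.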